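Three triazole analogues measured, a fourth awaiting cytotoxicity data

The compounds below may be only part of what the source reports. "The series", "measured", "known", "first", "only" and "open" are said of these compounds alone.

Compound 1: `CCCCCCc1cn(C(c2ccccc2)c2cc3cc(Br)ccc3nc2OC)nn1`, in an ADME assay on HeLa cells (Homo sapiens) for cytotoxicity, read by sulforhodamine B assay, with a stated time of 48 h, tested at 10 uM (on this read-out higher numbers stand for more inhibition at the one concentration tested (going by the name of the read-out) and lower numbers for less inhibition), compound 1 gives -0.97%.
Compound 2: `CCCCCc1cn(C(c2ccccc2)c2cc3cc(Br)ccc3nc2OC)nn1`, in this assay compound 2 gives -9.81%.
Compound 3: `COc1nc2ccc(Br)cc2cc1C(c1ccccc1)n1cc(CCCO)nn1`, in this assay compound 3 gives 11.3%.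

Compound 3 stands highest of the three numbers in this assay: a number 12.3 percentage points higher from compound 1 to compound 3 (beyond the scatter), and a number 21.1 percentage points higher from compound 2 to compound 3 (beyond the scatter), while a number 8.8 percentage points lower from compound 1 to compound 2 (within the scatter). The next compound, compound 4, is `COc1nc2ccc(Br)cc2cc1C(c1ccccc1)n1cc(-c2ccc(OC(F)(F)F)cc2)nn1`. Relative to compound 3 the change is 4-(trifluoromethoxy)phenyl in place of 3-hydroxypropyl on an aromatic carbon. The two steps that bear on it are those into compound 3, where the hydroxy group arrived and the number rose modestly; here that hydroxy leaves again and a large aromatic group arrives, so a modest fall in this assay is expected, with a number 11.3 percentage points lower from compound 3 to compound 4 (beyond the scatter) as the estimated step. Compound 4 is thus expected to give about 0% in this assay, within a range from -15% to 15%.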

Compound 4, a percentage reported as inhibition, at one concentration (the size of the read-out at that concentration, not a potency): -2.24%
Estimate against measurement, compound 4: 2.2 percentage points above; the measured number falls inside the stated range.
By their numbers in this assay, from the lowest: compounds 2, 4 and 1 (each within the scatter of the next); then compound 3.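

In this assay, 4-(trifluoromethoxy)phenyl in place of 3-hydroxypropyl on this aromatic carbon gives a number 13.5 percentage points lower from compound 3 to compound 4 (beyond the scatter) and so does not keep the higher number of compound 3. Set against the plain chains, the same group gives a number 7.6 percentage points higher from compound 2 to compound 4 (within the scatter) and a number 1.3 percentage points lower from compound 1 to compound 4 (within the scatter), so an aromatic ring here is not told apart from pentyl or hexyl, and only 3-hydroxypropyl stands apart. No measurement on hand explains this difference.

From the compounds shown here alone, it remains open whether the hydroxy group itself matters or the chain that carries it. An amine or a carboxylic acid at the end of the propyl chain, or a hydroxy group on the phenyl ring, would bear on that.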